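The compounds below may be only part of what the source reports. "The series", "measured", "known", "first", "only" and "open" are said of these compounds alone.

Measured so far, in an ADME assay on RAW264.7 cells (Mus musculus) for cytotoxicity, read by MTT assay, with a stated time of 24 h, tested at 10 ug/mL; a higher number here means a weaker effect of the compound at the concentration tested, a lower number a stronger effect:

compound 1, `COc1ccc(CCC(=O)c2cccc(O)c2)cc1`, gives 86.3%
compound 2, `COc1ccc(CCC(=O)c2cccc(O)c2)c(OC)c1`, gives 74.8%
compound 3, `COc1ccc(C(=O)CCc2ccc(OC)c(OC)c2)c(O)c1`, gives 67.5%

Compound 3 has the lowest number of the three in this assay. Its gap to compound 2 is within the scatter, so no order between those two is claimed; its gap to compound 1 lies beyond the scatter. How the core of compound 3 differs from that of compound 2 is not broken down here.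

One change is seen twice in the series. From compound 2 to compound 1 it is hydrogen in place of methoxy on an aromatic carbon, and in this assay it gave a number 11.5 percentage points higher from compound 2 to compound 1 (beyond the scatter). The unmeasured compound 4, `COc1ccc(CCC(=O)c2ccc(OC)cc2O)cc1`, is reached from compound 3 by hydrogen in place of methoxy on an aromatic carbon. The two sites are not the same: in the first case the carbon is ortho to a large group and meta to a methoxy group, in the second ortho to a methoxy group and meta to a large group, so this is the same kind of change rather than the same change.

Going by the values given here, with only one measured step to rest on, the step from compound 3 to compound 4 is expected to be about the same size as the earlier one, because a number 11.5 percentage points higher from compound 2 to compound 1 (beyond the scatter) is the only precedent; the expected step is a number 9.5 percentage points higher from compound 3 to compound 4 (within the scatter). Compound 4 is expected to give 77% in this assay, with a likely range of 66% to 88%.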

Compound 4, a percentage reported as activity, at one concentration (the size of the read-out at that concentration, not a potency): 88%
Beside the measured number, compound 4's estimate is 11 percentage points below it; the measured number falls inside the stated range.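

In this assay, hydrogen in place of methoxy on an aromatic carbon gave a number 20.5 percentage points higher from compound 3 to compound 4 (beyond the scatter), and this step runs the same way as the earlier one on the other core. Both steps lie beyond the scatter and their sizes cannot be told apart, so for these two pairs the change carries from one core to the other in direction, with no difference in size that can be claimed: the same change on two cores in this assay, a number 11.5 percentage points higher (beyond the scatter) from compound 2 to compound 1 and a number 20.5 percentage points higher (beyond the scatter) from compound 3 to compound 4, 9 percentage points apart, within the scatter of two such steps This rests on two pairs with the change at different sites, and each pair is read at a single concentration, so it shows neither a rule for other cores or other aromatic carbons nor any change in potency, and it does not say why the number rises.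

The compounds shown carry only methoxy, hydroxyl or hydrogen on their aromatic carbons, so it stays open how an amine, a carboxylic acid or a fluorine atom at these sites would read in this assay. As far as these compounds go, a longer chain between the carbonyl and the aromatic ring is also open, as is whether the same change would hold on such a chain-extended core.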